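The source may hold more compounds than are shown below. What is called first, only, known or untested is meant among the compounds shown, and "the series" means these compounds.

Compound 1 `CCOC(=O)C1=Cc2ccccc2OC1(OCc1cn(-c2cccc(OC)c2)nn1)C(F)(F)F` and compound 2 `CCCCCCCCn1cc(COC2(C(F)(F)F)Oc3ccccc3C=C2C(=O)OCC)nn1` share one core and differ by octyl in place of 3-methoxyphenyl on an aromatic nitrogen. In a functional assay on HeLa cells (Homo sapiens) for inhibition, read by MTT assay, with a stated time of 24 h (a lower number here means a stronger inhibitor, a higher number a weaker inhibitor), compound 1 gives only a limit, > 150000 nM. In this assay compound 2 likewise gives only a limit, > 150000 nM. The step that the two limits leave unreadable from compound 1 to compound 2 therefore cannot be read, since both values sit at the limit of > 150000 nM in this assay, at which 2 of the 2 values shown sit. Compound 3 `CCOC(=O)C1=Cc2ccccc2OC1(OCc1cn(CC(=O)Nc2ccc(I)cc2Cl)nn1)C(F)(F)F` differs from compound 2 by (2-chloro-4-iodophenyl)carbamoyl in place of heptyl on a saturated chain carbon bound to an aromatic nitrogen. Going by the values given here, no measured step bears on this change. Compound 3 is expected near 200000 nM, with a range from 50000 nM to 800000 nM. The step that the limit leaves unreadable from compound 2 to compound 3 is expected to remain unreadable against the limit.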

Compound 3, half-maximal inhibitory concentration: 26100 nM
Compound 3: the middle estimate sits 7.7-fold (0.88 log units) above what was measured, and the stated range ends above it.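

In this assay, ((2-chloro-4-iodophenyl)carbamoyl)methyl on the aromatic nitrogen gives the first measurable inhibition in this series, with an at least 5.7-fold lower number from compound 2 to compound 3 (0.75 log units; beyond the scatter) and an at least 5.7-fold lower number from compound 1 to compound 3 (0.75 log units; beyond the scatter). Neither 3-methoxyphenyl nor octyl at this position gave a readable value, so the step between those two cannot be read. Both steps to compound 3 give only a minimum size, as compound 1 and compound 2 remain limits: the limit of > 150000 nM in this assay, at which 2 of the 3 values shown sit.

On these data alone, whether the carbamoyl link or the chlorine and iodine carry the step stays open. An unsubstituted phenylcarbamoyl group or a carboxylic acid at this position would separate these parts.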